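The compounds below may be only part of what the source reports. "The series", "measured", "known", "first", "only" and "open" are said of these compounds alone.

Working notes on the series. Compound 1 `C[C@@H](C(=O)N1CCCCC1)N1CCN(S(=O)(=O)c2ccc(C(C)(C)C)cc2)CC1` carries piperidin-1-yl on the carbonyl carbon. In an ADME assay on HepG2 cells (Homo sapiens) for inhibition, with a stated time of 48 h (on this read-out lower numbers stand for an effect already at smaller amounts and higher numbers for an effect only at larger amounts of compound), compound 1 gives only a limit, > 40000 nM. Compound 2 `C[C@@H](C(=O)N1CCC(F)(F)CC1)N1CCN(S(=O)(=O)c2ccc(C(C)(C)C)cc2)CC1` likewise gives only a limit in this assay, > 40000 nM. The step that the two limits leave unreadable from compound 1 to compound 2 therefore cannot be sized. Compound 3 `CC1CCN(C(=O)C(C)N2CCN(S(=O)(=O)c3ccc(C(C)(C)C)cc3)CC2)CC1` also gives only a limit in this assay, > 40000 nM. It sits at the limit of > 40000 nM in this assay, at which 3 of the 3 values shown sit, as do the two other values. Compound 4 `CC(C(=O)N1CCc2ccccc2C1)N1CCN(S(=O)(=O)c2ccc(C(C)(C)C)cc2)CC1` differs from compound 3 by 1,2,3,4-tetrahydroisoquinolin-2-yl in place of 4-methylpiperidin-1-yl on a carbonyl carbon. Going by the values given here, no measured step bears on this change; the only one recorded is unreadable. Compound 4 is therefore expected to stay at the limit, with an estimated step that the limit leaves unreadable from compound 3 to compound 4. Compound 4 is estimated at 60000 nM, range 20000 nM to 200000 nM.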

Compound 4, half-maximal effective concentration: 29000 nM
Estimate against measurement, compound 4: 2.1-fold (0.32 log units) above; the measured number falls inside the stated range.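

In this assay, going by these compounds alone, the carbonyl carbon now gives a readable number for the first time, with 1,2,3,4-tetrahydroisoquinolin-2-yl, which brings an aromatic ring of carbon only, in place of 4-methylpiperidin-1-yl: an at least 1.3-fold lower number from compound 3 to compound 4 (0.13 log units; that floor lies within the scatter). Going by these compounds, the true size of this change stays unknown, as compound 3 gives only a limit. Compound 4 is the only compound shown that is off that limit: the limit of > 40000 nM in this assay, at which 3 of the 4 values shown sit.

Open, on these data alone, is whether the aromatic ring itself matters, or only the larger group. Also open, as far as these compounds go, is how a benzylamine or morpholin-4-yl on the carbonyl carbon would read.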